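The source may report more compounds than this note shows. Statements on the series, on what has been measured and on what is new or still open speak of the compounds shown alone.

Measured so far in an assay on HEK293 cells for agonist activity at Toll-like receptor 8 (Homo sapiens), read by a luciferase reporter, with a stated time of 6 h; a higher number here means that more compound is needed for the effect, a lower number that less compound is needed:
compound 1 `CCCCNc1nc(N)nc2c1CNCC2` — 7.2 uM
compound 2 `CCCCNc1nc(N)nc2c1CCNC2` — 0.6 uM
compound 3 `CCCCNc1nc(N)nc2c1CN(C(=O)c1ccccc1)CC2` — 1.4 uM

Compound 2 gives the lowest number of the three, and its gaps to compound 3 and to compound 1 both lie beyond the scatter. Compound 4 `CCCCNc1nc(N)nc2c1CCN(C(=O)c1ccccc1)C2` is not yet measured. It differs from compound 2 in one place: benzoyl in place of hydrogen on an amine nitrogen in a ring. Within the data shown here, compound 2 and compound 4 share their core with compound 1 and compound 3 only in the aromatic part; the saturated ring is joined differently, so the pair is a parallel of the one measured step rather than a repeat of it.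

Among the measured compounds shown here, that measured step is the one from compound 1 to compound 3, a 5.1-fold lower number from compound 1 to compound 3 (0.71 log units; beyond the scatter). Nothing else bears on the change. The lone precedent points to a lower number, and the same direction is expected for compound 4, with a size near the precedent but hedged toward a smaller effect, since one pair on a different core is all that is in hand. Compound 4 is therefore estimated at 0.2 uM, range 0.06 uM to 0.7 uM, meaning an expected step of a 3.0-fold lower number from compound 2 to compound 4 (0.48 log units; beyond the scatter).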

Compound 4, minimum effective concentration: 0.8 uM
Estimate against measurement, compound 4: 4.0-fold (0.60 log units) below, outside the stated range (above it).
By their numbers in this assay, from the lowest: compounds 2, 4 and 3 (each within the scatter of the next, the first and the last beyond it); then compound 1.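

In this assay, among these compounds, benzoyl in place of hydrogen on an amine nitrogen in a ring gives a 1.3-fold higher number from compound 2 to compound 4 (0.12 log units; within the scatter), so on this core the change stays within the scatter, whereas its only earlier instance lay beyond it. The outcome of this change therefore does not carry over from one core to the other, which a single pair could not show. The two instances differ by more than the scatter of two such steps allows, so the core in which the nitrogen sits has to be read together with the change itself: the same change on two cores in this assay, a 5.1-fold lower number (0.71 log units; beyond the scatter) from compound 1 to compound 3 and a 1.3-fold higher number (0.12 log units; within the scatter) from compound 2 to compound 4, 6.9-fold (0.84 log units) apart, beyond the scatter of two such steps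

From the compounds shown here alone, it remains open whether the same split between the two cores would appear with an acetyl group, a benzyl group or a longer acyl chain on that nitrogen, and such groups could separate the contribution of the aromatic ring from that of the carbonyl. Two pairs on two cores set no rule for any other group in this place.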